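A few compounds are considered here, and "the series" means these few. Any claim that something is new, unique, unknown or untested is made for them only; others in the source may bear on it.

Measured compounds:
Compound 1, `O=C(CSc1nnc(-c2ccncc2)o1)N/N=C/c1ccc(Cl)cc1`: 20500 nM
Compound 2, `O=C(CSc1nnc(-c2ccncc2)o1)N/N=C/c1cccc(F)c1`: 27500 nM

Among the compounds with values here, in a functional assay on BGC-823 cells (Homo sapiens) for cytotoxicity, read by MTT assay, with a stated time of 48 h (a higher number here means a weaker inhibitor, a lower number a stronger inhibitor), compound 2 gives 27500 nM, the higher of the two numbers so far, with compound 1 giving 20500 nM. The two stand close: a 1.3-fold higher number from compound 1 to compound 2 (0.13 log units; within the scatter), a difference within the usual scatter, so neither can be called the stronger inhibitor.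

Compound 3, `O=C(CSc1nnc(-c2ccncc2)o1)N/N=C/c1ccccc1[N+](=O)[O-]`, is not yet measured. It differs from compound 2 in one place: 2-nitrophenyl in place of 3-fluorophenyl on a carbon with a double bond to nitrogen. Within the data shown here, the only measured step, from compound 1 to compound 2, swapped one halogenated phenyl for another at this same carbon and moved the number hardly at all. Among the measured compounds shown here, no measured step brings a nitro group into this position, so the closest guide is that small swap on the same carbon. The expectation is therefore a change of no more than the scatter, in no certain direction; the step is estimated as a 1.1-fold lower number from compound 2 to compound 3 (0.04 log units; within the scatter). Compound 3 is expected to give about 25000 nM in this assay, with a likely range from 9000 nM to 70000 nM.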

Compound 3, half-maximal inhibitory concentration: 41600 nM
Compound 3: the middle estimate sits 1.7-fold (0.22 log units) below what was measured, within the range that was stated.
By their numbers in this assay, from the lowest: compounds 1, 2 and 3 (each within the scatter of the next, the first and the last beyond it).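

In this assay the 2-nitrophenyl group on this carbon gives a 1.5-fold higher number from compound 2 to compound 3 (0.18 log units; within the scatter) and also a 2.0-fold higher number from compound 1 to compound 3 (0.31 log units; beyond the scatter) when set against the 4-chlorophenyl group. Within the data shown here, this is the first step at this carbon to pass the scatter, and it runs towards a weaker inhibitor, though only modestly, and compound 2 cannot be told apart from either of its neighbours. Nothing available explains this small step.

The compounds shown leave open whether the step belongs to the nitro group itself or to where it sits on the ring, since they include no 3-nitrophenyl or 4-nitrophenyl partner for comparison. Also open, going by these compounds, is how this carbon would respond to a phenyl ring carrying an amine or a carboxylic acid, or to a plain alkyl chain in place of the ring.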